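Metabolic stability across three ester variants of one core

The source may report more compounds than this note shows. Statements on the series, on what has been measured and on what is new or still open speak of the compounds shown alone.

The study follows a series of esters built on a shared core, read in an ADME assay for metabolic stability, read by LC-MS, with a stated time of 3 h, at pH 6.5, tested at 50 uM; on this read-out lower numbers stand for a less stable compound and higher numbers for a more stable compound. Compound 1 `CC(C)OC(=O)c1cccc(NC(=O)[C@@H]2C[C@H](SC3=C(C(=O)O)N4C(=O)[C@H]([C@@H](C)O)[C@H]4[C@H]3C)CN2)c1` carries an isopropyl ester. In this assay compound 1 sits at the limit > 95%, which is a limit of the assay and not a number. Compound 2 `CC(C)C(=O)OCOC(=O)C1=C(S[C@@H]2CN[C@H](C(=O)Nc3cccc(C(=O)OCOC(=O)C(C)C)c3)C2)[C@H](C)[C@@H]2[C@@H]([C@@H](C)O)C(=O)N12` bears two (isopropylcarbonyl)oxy methylene esters. In this assay compound 2 likewise reaches the limit > 95%, a limit only. Compound 3 `Cc1oc(=O)oc1COC(=O)c1cccc(NC(=O)[C@@H]2C[C@H](SC3=C(C(=O)O)N4C(=O)[C@H]([C@@H](C)O)[C@H]4[C@H]3C)CN2)c1` replaces the isopropyl by a cyclic carbonate ester. In this assay compound 3 also sits at the limit > 95%, again a limit and not a number. The step that the two limits leave unreadable from compound 1 to compound 3 therefore cannot be read, as the limit of > 95% in this assay, at which 3 of the 3 values shown sit, shows.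

Compound 4 `CC(C)C(=O)OCOC(=O)c1cccc(NC(=O)[C@@H]2C[C@H](SC3=C(C(=O)O)N4C(=O)[C@H]([C@@H](C)O)[C@H]4[C@H]3C)CN2)c1` is the not yet measured partner of compound 3, differing by a group of 6 heavy atoms (4 carbon, 2 oxygen; no ring) in place of a group of 7 heavy atoms (4 carbon, 3 oxygen; one five-membered aromatic ring with 2 hetero atoms), on a saturated chain carbon bound to an oxygen next to a carbonyl group. Compound 2, which carries the same entering group at the same position, gives only a limit, so nothing constrains the change. The expected step of a number no higher from compound 3 to compound 4 (the limit leaves the size open) is taken as none beyond the scatter. Compound 4 is thus estimated at 95%, with a range from 85% to 98%.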

Compound 4, percent of the compound remaining: > 95%
Compound 4 was reported as a limit; the forecaster's own chance of this, stated with the estimate: 65%; the middle value lies on the limit itself.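

In this assay compound 4 sits at > 95%, a limit and not a number. No step from compound 1, compound 2 or compound 3 to compound 4 can be read: the limit of > 95% in this assay, at which 4 of the 4 values shown sit.

On these data alone, whether these ester groups on the shared core differ at all in this assay stays open.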